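Shortening the selenocyanate tether on a quinazoline scaffold

A few compounds are considered here, and "the series" means these few. Any claim that something is new, unique, unknown or untested is made for them only; others in the source may bear on it.

Compound 1 `COc1ccc(N(C)c2nc(C)nc3ccccc23)cc1OCCCCC[Se]C#N` carries its selenocyanate at the end of a chain attached through an oxygen on the aromatic ring. In a functional assay on A549 cells (Homo sapiens) for inhibition, read by MTT assay, with a stated time of 48 h (on this read-out higher numbers stand for weaker inhibition and lower numbers for stronger inhibition), compound 1 gives 2440 nM, the higher of the two numbers recorded. For the measured compounds named here, the other measured compound, compound 2 `CN(c1ccc([Se]C#N)cc1)c1nc(C2CC2)nc2ccccc12`, places the selenocyanate directly on the aromatic ring, and in this assay compound 2 gives 12 nM; the two values lie well beyond the scatter of each other, but as the two structures differ in several places at once no single step between them is recorded.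

Compound 3 `COc1ccc(N(C)c2nc(C)nc3ccccc23)cc1OCCC[Se]C#N` keeps the core of compound 1 and differs from it in one place: a group of 3 heavy atoms (1 carbon, 1 nitrogen, 1 selenium; no ring) in place of a group of 5 heavy atoms (3 carbon, 1 nitrogen, 1 selenium; no ring), on a saturated chain carbon, three bonds along the chain from an oxygen on an aromatic ring. Going by the values given here, no measured pair reports the effect of this change, so the expected step of a 1.1-fold lower number from compound 1 to compound 3 (0.04 log units; within the scatter) is small and within the scatter. Compound 3 is therefore estimated at 2200 nM, within a range from 700 nM to 7000 nM.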

Compound 3, half-maximal inhibitory concentration: 382 nM
For compound 3 the middle estimate is 5.8-fold (0.76 log units) above the measured one; measured number outside the range, below it.
By their numbers in this assay, from the lowest: compound 2; then compound 3; then compound 1.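

For the compounds shown here, compound 1 and compound 3 form the first pair here that differs in one place only, so the change in the tether can be read on its own. In this assay the step is a 6.4-fold lower number from compound 1 to compound 3 (0.81 log units; beyond the scatter) and it comes from the smaller group, on a saturated chain carbon, three bonds along the chain from an oxygen on an aromatic ring. Going by these compounds alone, the number at this position therefore responds to tether length by more than the scatter, which the earlier compounds, differing in several places at once, could not show. No measured property in the data bears on this step.

As far as these compounds go, whether a still shorter chain or a longer chain would follow the same direction remains open. So does whether a thiocyanate in place of the selenocyanate on this tether would give a similar number.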